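The source may hold more compounds than are shown below. What is called first, only, known or untested is meant among the compounds shown, and "the series" means these compounds.

In a functional assay on MCF7 cells (Homo sapiens) for antiproliferative activity, read by CCK-8 assay, with a stated time of 48 h (on this read-out higher numbers stand for weaker inhibition and lower numbers for stronger inhibition), compound 1 `C=CC(=O)NCCOc1ccc(Oc2c(-c3ccc(F)cc3)sc3cc(O)ccc23)cc1` gives 23000 nM and compound 2 `C/C=C/C(=O)NCCOc1ccc(Oc2c(-c3ccc(F)cc3)sc3cc(O)ccc23)cc1` gives 21700 nM, with a 1.1-fold lower number from compound 1 to compound 2 (0.03 log units; within the scatter). Compound 3 `O=C(/C=C/CNCCOc1ccc(Oc2c(-c3ccc(F)cc3)sc3cc(O)ccc23)cc1)N1CCC1` stands lowest of the three at 7340 nM. Compound 4 `O=C(/C=C/CNCCOc1ccc(Oc2c(-c3ccc(F)cc3)sc3cc(O)ccc23)cc1)N1CCCCC1` carries piperidin-1-yl in place of azetidin-1-yl on a carbonyl carbon, (piperidin-1-yl in place of azetidin-1-yl on a carbonyl carbon). Going by the values given here, no measured step changes this group alone. The nearest evidence is a 3.1-fold lower number from compound 1 to compound 3 (0.50 log units; beyond the scatter) and a 3.0-fold lower number from compound 2 to compound 3 (0.47 log units; beyond the scatter), but both exchange the whole group on the amine nitrogen and bear only loosely on this change. No step beyond the scatter is therefore expected in this assay, and no direction can be argued. The expected change is a 1.1-fold lower number from compound 3 to compound 4 (0.05 log units; within the scatter). Compound 4 is estimated at 6500 nM, with an expected range of 2800 nM to 15000 nM.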

Compound 4, half-maximal inhibitory concentration: 16400 nM
Compound 4: the middle estimate sits 2.5-fold (0.40 log units) below what was measured, outside the stated range (above it).
By their numbers in this assay, from the lowest: compound 3; then compounds 4, 2 and 1 (each within the scatter of the next).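

In this assay, going by these compounds alone, the group on the carbonyl carbon counts on its own: piperidin-1-yl in place of azetidin-1-yl gives a 2.2-fold higher number from compound 3 to compound 4 (0.35 log units; beyond the scatter) and lies beyond the scatter, which the earlier steps could not isolate. The prop-2-en-1-yl chain alone does not carry the difference, since a 1.3-fold lower number from compound 2 to compound 4 (0.12 log units; within the scatter) and a 1.4-fold lower number from compound 1 to compound 4 (0.15 log units; within the scatter) both lie within the scatter. Nothing available explains this ring dependence. Open, as far as these compounds go, is where pyrrolidin-1-yl, morpholin-4-yl or dimethylamino on the same carbonyl carbon would fall relative to compound 3 and compound 4.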